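Swapping an Ester Group on Two Related Cores

The source may report more compounds than this note shows. Statements on the series, on what has been measured and on what is new or still open speak of the compounds shown alone.

Measured so far:
compound 1 `CC1=C(C(=O)OC(C)(C)C)C(c2ccsc2)NC(=O)N1` gives 15% in an assay on membranes from CHO cells for displacement of a labelled ligand from adenosine receptor A1 (Homo sapiens), read by scintillation counting, with a stated time of 60 min, tested at 1 uM; on this read-out lower numbers stand for less inhibition and higher numbers for more inhibition at the one concentration tested (going by the name of the read-out)
compound 2 `CC1=C(C(=O)OCc2ccccc2)C(c2ccsc2)NC(=O)N1` gives 57% in this assay
compound 3 `CC1=C(C(=O)OC(C)(C)C)C(c2ccoc2)NC(=O)N1C` gives 21% in this assay

Compound 1 and compound 2 share one core, compound 3 and the unmeasured compound 4 `CC1=C(C(=O)OCc2ccccc2)C(c2ccoc2)NC(=O)N1C` share another; the difference between the two cores is not broken down here. Within the first pair, the change is benzyl in place of tert-butyl on an oxygen next to a carbonyl group. This step, a number 42 percentage points higher from compound 1 to compound 2 (beyond the scatter), is the only measured step among these compounds, and it is a large one.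

Compound 3 sits close to compound 1: in this assay compound 3 gives 21%, and that lies within the scatter of compound 1, so the two cannot be told apart on this read-out. Compound 2 stands well beyond both.

The change from compound 3 to compound 4 is benzyl in place of tert-butyl on an oxygen next to a carbonyl group, the same change as from compound 1 to compound 2, on the same kind of position. The expectation rests on one measured step only, so the step from compound 3 to compound 4 is estimated as a number 34 percentage points higher from compound 3 to compound 4 (beyond the scatter), expected in the same direction because of a number 42 percentage points higher from compound 1 to compound 2 (beyond the scatter), but with wide room around it since the core differs. Compound 4 is therefore expected to give about 55% in this assay, estimated to fall between 30% and 80%.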

Compound 4, a percentage reported as inhibition, at one concentration (the size of the read-out at that concentration, not a potency): 51%
For compound 4 the middle estimate is 4 percentage points above the measured one; low and high end bracket the measured number.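

Placing benzyl in place of tert-butyl on an oxygen next to a carbonyl group gives, in this assay, a number 30 percentage points higher from compound 3 to compound 4 (beyond the scatter), so the change points the same way on the core of compound 3 as it did on the core of compound 1. Set side by side, the two steps cannot be told apart in size, which means that on these two cores the change carries over in both direction and rough size: the same change on two cores in this assay, a number 42 percentage points higher (beyond the scatter) from compound 1 to compound 2 and a number 30 percentage points higher (beyond the scatter) from compound 3 to compound 4, 12 percentage points apart, within the scatter of two such steps

Within the data shown here, this does not show that the change would carry over to any further core, since it rests on one pair of compounds for each of only two cores, and it gives no reason for the rise, nor does it show which part of the difference between the cores matters, as compound 2 and compound 4 differ in more than one place.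

The compounds shown leave open whether the aromatic ring of the benzyl group is needed at all, which an ethyl group or a longer straight chain on the same oxygen could help to settle. They also leave open how a benzyl group carrying a chlorine atom on its ring, or an amide in place of the ester, would read in this assay.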